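Anilino for amino on the core of compound 3

This account rests on a few compounds, and the source may have more. Where it says the series, first, only, none or still open, it means among the compounds named here.

Among the compounds with values here, compound 3, `Cc1nc(N)nc(N[C@@H]2C[C@H](CO)[C@@H](O)[C@H]2O)c1-c1nc2ccccc2s1`, stands lowest of the two numbers that have been recorded, and its only neighbour is compound 1, a modestly higher number beyond the scatter. In an ADME assay on cells (Homo sapiens) for cytotoxicity, read by polymerase chain reaction, with a stated time of 3 days (a higher number here means that more compound is tolerated, a lower number that less compound is tolerated), compound 3 gives 4000 nM. Compound 1, `Nc1nc(Cl)c(-c2nc3ccccc3s2)c(N[C@@H]2C[C@H](CO)[C@@H](O)[C@H]2O)n1`, gives 14000 nM in this assay. The change of methyl in place of chloro on an aromatic carbon brought a 3.5-fold lower number from compound 1 to compound 3 (0.54 log units; beyond the scatter). Compound 2, `CCOc1ccc2nc(-c3c(Cl)nc(N)nc3N[C@@H]3C[C@H](CO)[C@@H](O)[C@H]3O)sc2c1`, reaches only a limit of this assay at > 25000 nM, that is the limit of > 25000 nM in this assay, at which 1 of the 3 values shown sits. The change of ethoxy in place of hydrogen on an aromatic carbon therefore gave an at least 1.7-fold higher number from compound 1 to compound 2 (0.25 log units; that floor lies within the scatter).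

Compound 4, `Cc1nc(Nc2ccccc2)nc(N[C@@H]2C[C@H](CO)[C@@H](O)[C@H]2O)c1-c1nc2ccccc2s1`, is obtained from compound 3 by the change (phenyl in place of hydrogen on a nitrogen on an aromatic ring). Neither of the measured steps touches a nitrogen on an aromatic ring, so neither bears directly on this change; the two steps were modest, one on an aromatic carbon of the core and the other on a distant aromatic carbon. Within the data shown here, with no guide of its own, a step of modest size toward a lower number is expected, since the only step beyond the scatter, methyl for chloro, lowered the number, and the estimate for compound 4 is given as a 1.6-fold lower number from compound 3 to compound 4 (0.20 log units; within the scatter). Compound 4 is therefore estimated at 2500 nM, within a range from 800 nM to 8000 nM.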

Compound 4, half-maximal cytotoxic concentration: > 25000 nM
Compound 4 gave a limit, no number; the forecaster's own chance of this, stated with the estimate: 5%; middle value at least 10-fold (1.00 log units) from the limit.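

Compound 4 stands at > 25000 nM in this assay, and that is a limit of the assay, not a number. Within the data shown here, no earlier step touched the nitrogen on an aromatic ring, and here phenyl in place of its hydrogen, amino to anilino, gives an at least 6.2-fold higher number from compound 3 to compound 4 (0.79 log units; beyond the scatter). This shows that the position responds in this assay, toward more compound tolerated, whereas the earlier step beyond the scatter, methyl in place of chloro on an aromatic carbon of the core, ran the other way; the new step is only a floor, and its full size cannot be read: the limit of > 25000 nM in this assay, at which 2 of the 4 values shown sit.

From the compounds shown here alone, whether the rise belongs to the phenyl ring itself, or would also come with a methyl, an acetyl or a benzyl on that nitrogen, stays open. Also open, going by these compounds, is whether the same amino to anilino change would move compound 1, which carries chloro where compound 3 carries methyl, and whether a phenyl bearing a methoxy or a carboxylic acid would leave the result at this limit.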